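Compound 1 to compound 3: a diethylamino tail

The compounds below may be only part of what the source reports. "The series", "measured", "known", "first", "only" and "open" are said of these compounds alone.

Measured so far:
Compound 1 `c1coc(CNc2nc(NCCCN3CCCC3)nc3ccccc23)c1` gives 35300 nM.
Compound 2 `Cc1cccc(N2CCN(CCCCNc3nc(NCc4ccco4)c4ccccc4n3)CC2)c1C` gives 1070 nM.

Both values come from a functional assay on DU-145 cells (Homo sapiens) for cytotoxicity, read by MTT assay, with a stated time of 2 days; on this read-out lower numbers stand for stronger inhibition and higher numbers for weaker inhibition. Compound 1 stands highest of the two numbers; compound 2 sits at a lower number, and the gap between compound 1 and compound 2 lies beyond the usual scatter of this assay. Among the compounds with values here, no pair of measured compounds differing in a single place is available, so nothing measured speaks directly to the size of a small change on the amine tail.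

Compound 3 `CCN(CC)CCNc1nc(NCc2ccco2)c2ccccc2n1` is the next compound to be tested in this assay. It differs from compound 1 by diethylamino in place of (pyrrolidin-1-yl)methyl on a saturated chain carbon, two bonds along the chain from a nitrogen on an aromatic ring. The change keeps the shared core and the furan-bearing side of compound 1 untouched and alters only the basic tail at its far end. Lacking any measured step of this kind, the step from compound 1 to compound 3 is expected to be a 1.1-fold lower number from compound 1 to compound 3 (0.04 log units; within the scatter), that is, no change beyond the scatter in either direction. For compound 3 the estimate in this assay is 32000 nM, expected to fall between 10000 nM and 100000 nM.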

Compound 3, half-maximal inhibitory concentration: > 100000 nM
Compound 3: a limit, no number; the forecaster's own chance of this, stated with the estimate: 10%; middle value at least 3.1-fold (0.49 log units) away from the limit.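

In this assay, within the data shown here, the exchange of (pyrrolidin-1-yl)methyl for diethylamino on a saturated chain carbon, two bonds along the chain from a nitrogen on an aromatic ring, gives the first measured step that differs in one place, and that step is an at least 2.8-fold higher number from compound 1 to compound 3 (0.45 log units; beyond the scatter). Compound 3 gives a limit and not a number, so the step fixes a direction and a minimum size but no exact size: the limit of > 100000 nM in this assay, at which 1 of the 3 values shown sits. Compound 1 and compound 2 differ in more than one place and could not show what this step shows, that replacing only the tail, with the shared core and the furan-bearing side unchanged, is enough to move the read-out beyond the scatter.

The same difference also reads as 3-(pyrrolidin-1-yl)propyl to 2-(diethylamino)ethyl, so the compounds shown leave open whether the step follows the loss of the ring, the shorter chain, or both. As far as these compounds go, a 3-(diethylamino)propyl tail on the same core would separate these two changes, and how far the number can fall on this tail, as it stands at 1070 nM for compound 2, also remains open.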